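Swapping the pendant group on the core of compound 1

The source may hold more compounds than are shown below. What is called first, only, known or untested is meant among the compounds shown, and "the series" means these compounds.

Compound 1 `COc1ccc(F)cc1CNCCCNc1ccnc2cc(Cc3ccc(C#N)cc3)ccc12` was tested in an ADME assay on HepG2 cells (Homo sapiens) for cytotoxicity, read by luminescence, CellTiter-Glo and ATP content, with a stated time of 72 h (a higher number here means that more compound is needed for the effect, a lower number that less compound is needed), and gives 6050 nM. Among the three measured compounds this is the second highest number; compound 3 `COc1cccc(CNCCCNc2ccnc3cc(Cc4ccc(C#N)cc4)ccc23)c1O` gives 7150 nM, and the step of a 1.2-fold higher number from compound 1 to compound 3 (0.07 log units; within the scatter) lies within the scatter, while compound 2 `COc1ccc(-c2ccc3c(NCCCNCc4cccc(OC)c4O)ccnc3c2)cc1` gives 1600 nM, a clearly lower number than compound 1.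

Compound 4 `COc1ccc(F)cc1CNCCCNc1ccnc2cc(Oc3ccccc3)ccc12` differs from compound 1 at a single place: phenoxy in place of 4-cyanobenzyl on an aromatic carbon. Going by the values given here, the one measured step that touches this same aromatic carbon is a 4.5-fold higher number from compound 2 to compound 3 (0.65 log units; beyond the scatter), which shows that exchanging the group at this position can move the number by a modest amount. The other step, a 1.2-fold higher number from compound 1 to compound 3 (0.07 log units; within the scatter), concerns a different part of the molecule and stayed within the scatter. On this basis a modest shift toward a lower number is expected for compound 4, as in a 1.7-fold lower number from compound 1 to compound 4 (0.24 log units; within the scatter), though with wide uncertainty. Compound 4 is therefore estimated at 3500 nM, with a range from 1500 nM to 9000 nM.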

Compound 4, half-maximal effective concentration: 1500 nM
The estimate for compound 4 lay 2.3-fold (0.37 log units) above the measured number, and the stated range covers the measured number.
By their numbers in this assay, from the lowest: compounds 4 and 2 (each within the scatter of the next); then compounds 1 and 3 (each within the scatter of the next).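

With the 5-fluoro-2-methoxyphenyl end of the molecule unchanged, replacing 4-cyanobenzyl with phenoxy on this aromatic carbon gives a 4.0-fold lower number from compound 1 to compound 4 (0.61 log units; beyond the scatter) in this assay. This is a second step beyond the scatter at this carbon, and it points the same way as a 4.5-fold higher number from compound 2 to compound 3 (0.65 log units; beyond the scatter): in both pairs, the compound carrying 4-cyanobenzyl has the higher number, even though the other end of the molecule differs between the pairs. No measurement shown gives a cause for this shift.

Phenoxy differs from 4-cyanobenzyl in both its oxygen link and its lack of a nitrile, so these compounds cannot separate the two changes; plain benzyl or 4-cyanophenoxy at this carbon would do so. Going by these compounds, it also remains open whether phenoxy would lower the number in the same way when paired with the 2-hydroxy-3-methoxyphenyl end.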